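Removing the Trifluoromethyl Group: What to Expect for Compound 4

The source may report more compounds than this note shows. Statements on the series, on what has been measured and on what is new or still open speak of the compounds shown alone.

Compound 2 `O=C(CN1CCCC1)Nc1ccc(-c2nc3cc(C(F)(F)F)ccc3[nH]2)cc1` gives 18000 nM in an ADME assay on MT4 cells (Homo sapiens) for cytotoxicity, read by MTT assay, with a stated time of 96 h; on this read-out higher numbers stand for lower toxicity in this test and lower numbers for higher toxicity in this test. Of the three measured compounds it has the second highest number: compound 3 `CC(=O)Nc1ccc(-c2nc3cc(C(F)(F)F)ccc3[nH]2)cc1` gives 19000 nM, and a 1.1-fold higher number from compound 2 to compound 3 (0.02 log units; within the scatter). Compound 1 `O=C(CN1CCCCC1)Nc1ccc(-c2nc3cc(C(F)(F)F)ccc3[nH]2)cc1` gives 6000 nM, and a 3.0-fold higher number from compound 1 to compound 2 (0.48 log units; beyond the scatter), while a 3.2-fold higher number from compound 1 to compound 3 (0.50 log units; beyond the scatter).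

Compound 4 `O=C(CN1CCCC1)Nc1ccc(-c2nc3ccccc3[nH]2)cc1` differs from compound 2 in one place: hydrogen in place of trifluoromethyl on an aromatic carbon. Among the compounds with values here, each measured step changes the group on the saturated chain carbon bound to the carbonyl carbon, and none touches the trifluoromethyl, so no measured step bears directly on this change. In this assay, compound 4 is therefore expected to give 18000 nM, between 6000 nM and 50000 nM, an estimated step of no change at the digits printed from compound 2 to compound 4 (within the scatter) that stays within the scatter.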

Compound 4, half-maximal cytotoxic concentration: 40000 nM
Compound 4: middle estimate off by 2.2-fold (0.35 log units), on the low side, within the range that was stated.
By their numbers in this assay, from the lowest: compound 1; then compounds 2 and 3 (each within the scatter of the next); then compound 4.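

The earlier steps shown here changed only the group on the saturated chain carbon, whereas this one shows that the aromatic carbon carrying trifluoromethyl also matters in this assay. Hydrogen in place of trifluoromethyl gives a 2.2-fold higher number from compound 2 to compound 4 (0.35 log units; beyond the scatter), a modest shift towards lower toxicity in this test. Nothing available explains this shift.

Still open, going by these compounds, is whether a chlorine atom, a methoxy group or a nitrile on this carbon would shift the number in the same way. On these data alone, it is also open whether the same change would give a similar step with piperidin-1-yl on the chain.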